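A few compounds are considered here, and "the series" means these few. Any claim that something is new, unique, unknown or untested is made for them only; others in the source may bear on it.

Compound 1 `O=C(Nc1ccncc1)Nc1ccccc1O` in a functional assay on the whole organism with Mus musculus as the target, in the maximal electroshock model, with a stated time of 30 min (a higher number here means that more compound is needed for the effect, a lower number that less compound is needed), gives only a limit, > 300 mg/kg.
Compound 2 `O=C(Nc1ccncc1)Nc1ccc([N+](=O)[O-])cc1` in this assay gives only a limit, > 300 mg/kg.

Compound 2 thus stands at the limit of the assay rather than at a number, as does the other value shown (the limit of > 300 mg/kg in this assay, at which 2 of the 2 values shown sit). Within the data shown here, no step between measured compounds is available. Compound 3 `Nc1ccc(NC(=O)Nc2ccncc2)cc1` differs from compound 2 by one change (amino in place of nitro on an aromatic carbon). Among the measured compounds shown here, with no measured step to lean on, the expected step in this assay is none beyond the scatter, and compound 3 is expected to sit at the limit too. For compound 3 the estimated minimum effective dose is 300 mg/kg, ranging from 100 mg/kg to 600 mg/kg. The expected step is a number no higher from compound 2 to compound 3 (the limit leaves the size open).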

Compound 3, minimum effective dose: > 300 mg/kg
Compound 3: only a limit was reported (the forecaster's own chance of this, stated with the estimate: 70%); the middle value lies on the limit itself.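

Compound 2 and compound 3 both give only a limit in this assay, so no step between them can be read: the limit of > 300 mg/kg in this assay, at which 3 of the 3 values shown sit.

The compounds shown leave open what minimum effective dose any of them has, and whether amino in place of nitro changes it.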